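The source may report more compounds than this note shows. Statements on the series, on what has been measured and on what is new or still open speak of the compounds shown alone.

Of the compounds shown here, three sharing one core have been measured in an assay on CHO cells for binding affinity to Alpha-2C adrenergic receptor (Homo sapiens), read by radioligand binding; on this read-out higher numbers stand for weaker inhibition and lower numbers for stronger inhibition. Compound 1 `CSc1ccc(F)cc1NCC1=NCCN1` carries a fluoro group and gives 115 nM; compound 2 `COc1ccc(SC)c(NCC2=NCCN2)c1` carries a methoxy group in the matching place and gives 603 nM; compound 3 `CSc1ccc(Cl)cc1NCC1=NCCN1` carries a chloro group and gives 170 nM. Among these three numbers compound 3 stands second highest: its nearest neighbour is compound 1, with a 1.5-fold higher number from compound 1 to compound 3 (0.17 log units; within the scatter), a step that stays within the scatter of repeated measurements, while the step of a 3.5-fold lower number from compound 2 to compound 3 (0.55 log units; beyond the scatter) lies beyond it.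

Compound 4 `CSc1ccc(C(F)(F)F)cc1NCC1=NCCN1` takes the next step from compound 3: trifluoromethyl in place of chloro on an aromatic carbon. The change sits on an aromatic carbon of a six-membered aromatic ring of carbon only, para to a methylsulfanyl group.

Within the data shown here, two measured steps bear on this change, both at the same place. Exchanging one halogen for another, fluoro for chloro, left the number essentially unchanged, as shown by a 1.5-fold higher number from compound 1 to compound 3 (0.17 log units; within the scatter). Putting methoxy there instead of chloro moved the number by a 3.5-fold lower number from compound 2 to compound 3 (0.55 log units; beyond the scatter). Trifluoromethyl has not been tried at this place, so the expectation in this assay rests on the observation that the two halogens behaved alike. A step of about a 1.3-fold higher number from compound 3 to compound 4 (0.11 log units; within the scatter) is therefore expected, within or just beyond the scatter. For compound 4 the estimated value is 220 nM, with a range from 80 nM to 600 nM.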

Compound 4, inhibition constant: 603 nM
Beside the measured number, compound 4's estimate is 2.7-fold (0.44 log units) below it; measured number above the stated range.
By their numbers in this assay, from the lowest: compounds 1 and 3 (each within the scatter of the next); then compounds 2 and 4 (each within the scatter of the next).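

In this assay, the exchange of chloro for trifluoromethyl is not the quiet swap that fluoro for chloro was: the result is a 3.5-fold higher number from compound 3 to compound 4 (0.55 log units; beyond the scatter), and measured from the fluoro compound it is a 5.2-fold higher number from compound 1 to compound 4 (0.72 log units; beyond the scatter). Trifluoromethyl instead lands level with methoxy, with no change at the digits printed from compound 2 to compound 4 (within the scatter), so at this place on the ring the four compounds fall into two pairs, the two halogens together and methoxy together with trifluoromethyl, and the likeness of fluoro and chloro does not carry over to a group that merely contains fluorine. Nothing available here accounts for this split into two pairs.

With only four groups at this one place, two pairs cannot show whether methoxy and trifluoromethyl match for a shared reason or by coincidence. A bromo, methyl or amino group at the same place would show which pair each one joins, and whether the split holds at all or the values instead spread out along a range.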